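The source may hold more compounds than are shown below. What is called first, only, known or untested is meant among the compounds shown, and "the series" means these compounds.

Measured in an ADME assay on the whole organism (Mus musculus, strain CD1) for pharmacokinetics, at a dose of 2 mg/kg by the intravenous route; a lower number here means slower removal, a higher number faster removal of the compound:
Compound 1 `CN1CCC(Oc2ccc(N3C(=S)N(c4cnc(C#N)c(C(F)(F)F)c4)C(=O)C34CCC4)cc2)CC1`: 4.12 mL/min/kg
Compound 2 `CN1CCC(Oc2ccc(N3C(=S)N(c4cnc(C#N)c(C(F)(F)F)c4)C(=O)C34CCC4)cn2)CC1`: 8.14 mL/min/kg
Compound 3 `N#Cc1ncc(N2C(=O)C3(CCC3)N(c3ccc(CN4CCNCC4)cc3)C2=S)cc1C(F)(F)F`: 18.2 mL/min/kg

Compound 1 stands at the low end of this small set. Its number lies within the usual scatter of compound 2, so those two cannot be told apart, while compound 3 lies clearly apart: a 4.4-fold higher number from compound 1 to compound 3 (0.65 log units; beyond the scatter).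

The next compound to be measured is compound 4 `COc1cc(N2C(=O)C3(CCC3)N(c3ccc(OC4CCN(C)CC4)cc3)C2=S)cnc1C#N`. It differs from compound 1 in one place: methoxy in place of trifluoromethyl on an aromatic carbon. In words, methoxy takes the place of trifluoromethyl, ortho to a cyano group.

Going by the values given here, none of the measured steps touches this group. Among the compounds with values here, the only step available swaps (1-methylpiperidin-4-yl)oxy for (piperazin-1-yl)methyl, and it shows only that a single change can move this assay by a modest amount. It gives no direct guide to the new change. Compound 1, at 4.12 mL/min/kg, has no measured neighbour with a clearly lower number, so a slight lean upward is expected, but nothing firm. The expected change, which stays within the scatter, is a 1.8-fold higher number from compound 1 to compound 4 (0.26 log units; within the scatter). For compound 4 the estimate is 7.5 mL/min/kg, with an expected range from 3 mL/min/kg to 19 mL/min/kg.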

Compound 4, clearance: 6.9 mL/min/kg
Compound 4: middle estimate off by 1.1-fold (0.04 log units), on the high side, and the stated range covers the measured number.
By their numbers in this assay, from the lowest: compounds 1, 4 and 2 (each within the scatter of the next); then compound 3.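

In this assay, putting methoxy in place of trifluoromethyl gives a 1.7-fold higher number from compound 1 to compound 4 (0.22 log units; within the scatter), so this change, ortho to a cyano group and two atoms from the ring nitrogen, cannot be told apart from no change at all. Going by these compounds alone, this is the first measured step at this position, and it shows that the group there can lose heavy atoms and gain a hydrogen-bond acceptor, the differences counted between these two groups, without a shift in this number that stands clear of the scatter. No measurement at hand offers any explanation for this outcome.

The compounds shown leave open whether this holds for other groups at the same position, such as an amine, a carboxylic acid, a single chlorine atom or a longer chain like ethoxy, because a single replacement says little about the range of groups that would behave alike. They also leave open whether the same swap would stay within the scatter when made on compound 2 or compound 3, whose numbers in this assay differ from that of compound 1 in the other parts of the molecule.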